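Extending the acrylamide of compound 1 with a methylpiperazinyl chain

This account rests on a few compounds, and the source may have more. Where it says the series, first, only, none or still open, it means among the compounds named here.

Measured so far:
compound 1, `C=CC(=O)Nc1cc2c(N3CCc4ccccc43)ncnc2cc1OC`: 5940 nM
compound 2, `C=CC(=O)Nc1cc2c(N3CCc4ccccc43)ncnc2cc1O[C@@H]1CCOC1`: 2710 nM
compound 3, `CC(C)/C=C/C(=O)Nc1cc2c(N3CCCc4ccccc43)ncnc2cc1O[C@@H]1CCOC1`: 8510 nM

In a functional assay on PC-3 cells (Homo sapiens) for antiproliferative activity, read by MTT assay, with a stated time of 72 h (a higher number here means a weaker inhibitor, a lower number a stronger inhibitor), compound 1 gives 5940 nM, the second highest of the three numbers; compound 2 sits lower, and compound 3 lies within the scatter of compound 1. Compound 4, `COc1cc2ncnc(N3CCc4ccccc43)c2cc1NC(=O)/C=C/CN1CCN(C)CC1`, keeps the core and the methoxy group of compound 1 but differs at the acrylamide: 3-(4-methylpiperazin-1-yl)prop-1-en-1-yl in place of vinyl on a carbonyl carbon. Among the compounds with values here, the only single-point step measured, a 2.2-fold lower number from compound 1 to compound 2 (0.34 log units; beyond the scatter), concerns the ether and not the amide, so no measured step bears directly on this change; compound 3 alters two places at once and cannot isolate it. A step of uncertain direction is therefore expected, a 1.5-fold lower number from compound 1 to compound 4 (0.17 log units; within the scatter), and compound 4 is estimated at 4000 nM, ranging from 1500 nM to 11000 nM.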

Compound 4, half-maximal inhibitory concentration: 9180 nM
For compound 4 the middle estimate is 2.3-fold (0.36 log units) below the measured one, within the range that was stated.
By their numbers in this assay, from the lowest: compound 2; then compounds 1, 3 and 4 (each within the scatter of the next).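

In this assay, putting 3-(4-methylpiperazin-1-yl)prop-1-en-1-yl in place of vinyl on a carbonyl carbon gives a 1.5-fold higher number from compound 1 to compound 4 (0.19 log units; within the scatter), the first single-place step read at the amide rather than the ether. This place therefore accepts the larger group, with its six-membered non-aromatic ring, without a shift beyond the scatter. No available measurement explains this result. Still open, on these data alone, is whether a dimethylamino or morpholine group at the end of the chain would behave in the same way, and whether this chain combined with oxolan-3-yl on the oxygen would read differently.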